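Replacing bis(2-hydroxyethyl)amino with methoxy on the carbonyl carbon

The source may hold more compounds than are shown below. What is called first, only, known or untested is meant among the compounds shown, and "the series" means these compounds.

In a functional assay on SW-620 cells (Homo sapiens) (on this read-out higher numbers stand for weaker inhibition and lower numbers for stronger inhibition), compound 1 `COc1cc(NC(C)CCCNC(=O)NCCCCCO)c2ncccc2c1` gives 200 nM. In this assay compound 2 `COc1cc(NC(C)CCCNC(=O)NOCc2ccccc2)c2ncccc2c1` gives 20000 nM. In this assay compound 3 `COc1cc(NC(C)CCCNC(=O)N(CCO)CCO)c2ncccc2c1` gives > 100000 nM, which is a limit and not a number. Compound 3 therefore stands at the limit of > 100000 nM in this assay, at which 1 of the 3 values shown sits.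

Compound 4 `COC(=O)NCCCC(C)Nc1cc(OC)cc2cccnc12` differs from compound 3 by methoxy in place of bis(2-hydroxyethyl)amino on a carbonyl carbon.

For the measured compounds named here, no measured step makes this exact change. The closest ones also remove bis(2-hydroxyethyl)amino from the carbonyl carbon, read in reverse: an at least 500-fold higher number from compound 1 to compound 3 (2.69 log units; beyond the scatter) and an at least 5.0-fold higher number from compound 2 to compound 3 (0.69 log units; beyond the scatter). Both end at a limit, so their true sizes are open. The step of a 100-fold higher number from compound 1 to compound 2 (2.00 log units; beyond the scatter) shows that the low number of compound 1 does not survive a change of its 5-hydroxypentyl group, and compound 4 lacks that group too.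

A move toward a lower number is expected, closer in size to the smaller of these steps, and a second limit remains possible. The expected step is an at least 3.3-fold lower number from compound 3 to compound 4 (0.52 log units; beyond the scatter). For compound 4 the estimated value is 30000 nM, with an expected range of 6000 nM to 100000 nM.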

Compound 4, half-maximal inhibitory concentration: > 100000 nM
Compound 4: a limit, no number; the forecaster's own chance of this, stated with the estimate: 40%; at least 3.3-fold (0.52 log units) between middle value and limit.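

In this assay compound 4 gives > 100000 nM, which is a limit of the assay and not a number. Methoxy in place of bis(2-hydroxyethyl)amino on the carbonyl carbon therefore yields no readable value, and the step between compound 3 and compound 4 cannot be read: the limit of > 100000 nM in this assay, at which 2 of the 4 values shown sit.

Methoxy in place of (5-hydroxypentyl)amino gives an at least 500-fold higher number from compound 1 to compound 4 (2.69 log units; beyond the scatter), and methoxy in place of (benzyloxy)amino gives an at least 5.0-fold higher number from compound 2 to compound 4 (0.69 log units; beyond the scatter), so readable values remain confined to compound 1 and compound 2, which keep the amide hydrogen on that nitrogen.

On these data alone, how compound 3 and compound 4 rank against each other remains open. Also open, as far as these compounds go, is whether compound 1 owes its low value to the hydroxyl or to the chain of its 5-hydroxypentyl group, a question that a plain pentylamino group on the same carbonyl carbon would address.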